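A nitro-to-trifluoromethyl swap on a weak antiproliferative series

The source may report more compounds than this note shows. Statements on the series, on what has been measured and on what is new or still open speak of the compounds shown alone.

Of the compounds shown here, two sharing one core have been tested in a functional assay on SH-SY5Y cells (Homo sapiens) for antiproliferative activity, read by MTT assay, with a stated time of 72 h; a higher number here means a weaker inhibitor, a lower number a stronger inhibitor. Compound 1 `c1ccc(COc2ccccc2Nc2ncnc3cc4c(cc23)OCCOCCO4)cc1` gives 93700 nM. Compound 2 `O=[N+]([O-])c1ccc(COc2ccccc2Nc2ncnc3cc4c(cc23)OCCOCCOCCO4)cc1` gives 75500 nM. Compound 2 carries the lower of the two numbers, but the gap to compound 1 lies within the usual scatter of repeated measurements, so the two cannot be told apart on these data, and both sit at the weak end of the range.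

Compound 3 `FC(F)(F)c1ccc(COc2ccccc2Nc2ncnc3cc4c(cc23)OCCOCCOCCO4)cc1` has not yet been measured. It differs from compound 2 in one place: trifluoromethyl in place of nitro on an aromatic carbon. The change sits on an aromatic carbon of a six-membered aromatic ring of carbon only, para to a large group, on the (4-nitrobenzyl)oxy arm that becomes (4-(trifluoromethyl)benzyl)oxy.

Among the measured compounds shown here, no measured pair in this set isolates such a change, so nothing here shows how this assay responds to it. Compound 3 is therefore expected to stay close to compound 2, with a step of a 1.1-fold lower number from compound 2 to compound 3 (0.03 log units; within the scatter) that does not exceed the scatter in either direction. The estimate for compound 3 is 70000 nM, ranging from 30000 nM to 160000 nM.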

Compound 3, half-maximal inhibitory concentration: > 100000 nM
Compound 3 ended at the assay's limit; the forecaster's own chance of this, stated with the estimate: 15%; middle value at least 1.4-fold (0.15 log units) away from the limit.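

In this assay compound 3 gives > 100000 nM, which is a limit of the assay and not a number: the limit of > 100000 nM in this assay, at which 1 of the 3 values shown sits. Trifluoromethyl in place of nitro, on an aromatic carbon para to a large group, gives the first step that can be read at this position, an at least 1.3-fold higher number from compound 2 to compound 3 (0.12 log units; that floor lies within the scatter), so the true size of the change remains unknown, and it may or may not exceed the usual scatter. What the result does show is that this swap yields no sign of a stronger inhibitor and leaves the (4-(trifluoromethyl)benzyl)oxy compound at the weak end of the range.

The compounds shown leave open whether any group on this aromatic carbon can bring the number down, for instance an amine, a carboxylic acid or a nitrile. Among the compounds shown here, they also leave open how a longer chain in place of the (4-(trifluoromethyl)benzyl)oxy arm would read, and with only one step at this position, no trend across groups can be drawn here.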